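This account rests on a few compounds, and the source may have more. Where it says the series, first, only, none or still open, it means among the compounds named here.

Compound 1 `NC(=S)Nc1cccc(OCCCCCN2CCN(c3ccc(C4CCCCC4)cc3)C2=S)c1` sits at the assay limit, > 50000 nM, in an ADME assay on Huh-7 cells (Homo sapiens) for cytotoxicity; a lower number here means that less compound is tolerated, a higher number that more compound is tolerated.
Compound 2 `NC(=S)Nc1cccc(OCCCCCCCCNC(=S)Nc2cccc(Br)c2)c1` gives 20000 nM.
Compound 3 `NC(=S)Nc1cccc(OCCCCCCCCNC(=S)Nc2ccc(C3CCCCC3)cc2)c1` likewise sits at the limit, > 50000 nM.

Among these three values compound 2 holds the only number; the other two are limits, which is the situation described by the limit of > 50000 nM in this assay, at which 2 of the 3 values shown sit. Compound 4 `NC(=S)Nc1cccc(OCCCCCCCCNC(=S)Nc2ccc3[nH]ccc3c2)c1` differs from compound 2 by 1H-indol-5-yl in place of 3-bromophenyl on an amide-type nitrogen. For the measured compounds named here, no step between measured compounds is available. The estimate here is a modest move upward, of a size within or just beyond the scatter, written as a 1.5-fold higher number from compound 2 to compound 4 (0.18 log units; within the scatter). Compound 4 is therefore expected at 30000 nM, within a range from 10000 nM to 60000 nM.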

Compound 4, half-maximal cytotoxic concentration: 18000 nM
Beside the measured number, compound 4's estimate is 1.7-fold (0.22 log units) above it, within the range that was stated.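

In this assay, replacing 3-bromophenyl with 1H-indol-5-yl on an amide-type nitrogen gives a 1.1-fold lower number from compound 2 to compound 4 (0.05 log units; within the scatter). This position therefore takes a group with a second aromatic ring and a hydrogen-bond donor without a step beyond the scatter. Compound 2 and compound 4 both give numbers, so this step can be read, which is not so for the other compounds shown: the limit of > 50000 nM in this assay, at which 2 of the 4 values shown sit.

From the compounds shown here alone, whether a group carrying an amine or a carboxylic acid in this place would also stay within the scatter remains open. So does the effect of a longer chain on this pair.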